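Urea Series on Lung Carcinoma Cells: Predicting a Trifluoromethyl Analogue

This account rests on a few compounds, and the source may have more. Where it says the series, first, only, none or still open, it means among the compounds named here.

Measured compounds:
compound 1 `COc1cc(Cl)cc(-c2nn(-c3cccc(NC(=O)c4ccc(Cl)c(Cl)c4)c3)cc2-c2ccncc2)c1` gives 105%
compound 2 `COc1cc(Cl)cc(-c2nn(-c3cccc(NC(=O)Nc4ccc(Cl)c(C(F)(F)F)c4)c3)cc2-c2ccncc2)c1` gives 13.5%
compound 3 `COc1cc(Cl)cc(-c2nn(-c3cccc(NC(=O)Nc4ccc(Cl)c(Cl)c4)c3)cc2-c2ccncc2)c1` gives 15.7%

In a functional assay on HOP-62 cells (Homo sapiens) for inhibition, read by sulforhodamine B assay, with a stated time of 48 h, tested at 10 uM (on this read-out lower numbers stand for a stronger effect and higher numbers for a weaker effect at the one concentration tested), compound 3 stands second highest of the three numbers. Its nearest neighbour is compound 2, and the difference a number 2.2 percentage points higher from compound 2 to compound 3 (within the scatter) lies within the scatter, so no order between them can be claimed. Its furthest neighbour is compound 1, from which compound 3 is reached by a number 89.3 percentage points lower from compound 1 to compound 3 (beyond the scatter), while compound 2 is reached from compound 1 by a number 91.5 percentage points lower from compound 1 to compound 2 (beyond the scatter); both of these steps exchange an aryl amide for an aryl urea.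

Compound 4 `COc1cc(Cl)cc(-c2nn(-c3cccc(NC(=O)Nc4cccc(C(F)(F)F)c4)c3)cc2-c2ccncc2)c1` has not yet been measured. It differs from compound 3 as follows: 3-(trifluoromethyl)phenyl in place of 3,4-dichlorophenyl on an amide-type nitrogen. The urea is kept, so the two large steps from compound 1 do not bear on it directly. For the measured compounds named here, the one step that does, the exchange of chloro for trifluoromethyl on the aromatic carbon between compound 2 and compound 3, was within the scatter. A step of similar size is therefore expected, a number 4.3 percentage points higher from compound 3 to compound 4 (within the scatter), in no firm direction. For compound 4 the estimate is 20%, within a range of 8% to 45%.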

Compound 4, a percentage reported as activity, at one concentration (the size of the read-out at that concentration, not a potency): 15.5%
Beside the measured number, compound 4's estimate is 4.5 percentage points above it, and the stated range covers the measured number.
By their numbers in this assay, from the lowest: compounds 2, 4 and 3 (each within the scatter of the next); then compound 1.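

On the amide-type nitrogen of the urea, 3-(trifluoromethyl)phenyl can take the place of 3,4-dichlorophenyl in this assay with no readable change, a number 0.2 percentage points lower from compound 3 to compound 4 (within the scatter). The chloro of compound 2 is likewise not needed to keep the effect, as its replacement by hydrogen gives a number 2 percentage points higher from compound 2 to compound 4 (within the scatter), while the urea again stands apart from the aryl amide, a number 89.5 percentage points lower from compound 1 to compound 4 (beyond the scatter). Nothing at hand accounts for why these aryl exchanges leave the read-out in place.

With all three ureas within the scatter of one another at a single concentration, whether any of them has a stronger or weaker effect at that concentration than the others remains unresolved. From the compounds shown here alone, it also remains open whether a carboxylic acid or an amine on this aryl ring would keep the effect.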